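Benzylamino in place of dipentylamino on the shared core

A few compounds are considered here, and "the series" means these few. Any claim that something is new, unique, unknown or untested is made for them only; others in the source may bear on it.

Compound 1, `CC(C)N(c1nc2c(ncn2-c2ccccc2)c(=O)n1-c1ccccc1)C(C)C`, gives 53500 nM in a functional assay on KB cells (Homo sapiens) for cytotoxicity, read by MTT assay, with a stated time of 72 h; on this read-out lower numbers stand for stronger inhibition and higher numbers for weaker inhibition.
Compound 2, `CCCCCN(CCCCC)c1nc2c(ncn2-c2ccccc2)c(=O)n1-c1ccc(Cl)cc1`, gives 10600 nM in this assay.

Of the two numbers shown, compound 2 stands lowest, so it is the stronger of the pair in this assay, and the gap to compound 1 lies beyond the usual scatter. For the measured compounds named here, compound 2 carries a dipentylamino group and a 4-chlorophenyl group, while compound 1 carries a diisopropylamino group and a phenyl group, so the two differ in more than one place and no single step between them can be read off.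

The next compound, compound 3, is `O=c1c2ncn(-c3ccccc3)c2nc(NCc2ccccc2)n1-c1ccc(Cl)cc1`. It keeps the 4-chlorophenyl group of compound 2 and changes only the amino substituent: benzylamino in place of dipentylamino on an aromatic carbon. Going by the values given here, no step of this kind is available among the measured compounds, so the size of the change has to be guessed. Compound 3 is expected to land near compound 2, with a step of a 1.3-fold lower number from compound 2 to compound 3 (0.12 log units; within the scatter) that stays within or only slightly beyond the scatter. Compound 3 is therefore estimated at 8000 nM, with a range from 2000 nM to 40000 nM.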

Compound 3, half-maximal inhibitory concentration: 34300 nM
For compound 3 the middle estimate is 4.3-fold (0.63 log units) below the measured one; the measured number falls inside the stated range.
By their numbers in this assay, from the lowest: compound 2; then compounds 3 and 1 (each within the scatter of the next).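

For the compounds shown here, this is the first step in the set that can be read at a single place. In this assay, the change gives a 3.2-fold higher number from compound 2 to compound 3 (0.51 log units; beyond the scatter) and so shows that the amino substituent on this aromatic carbon, ortho to a 4-chlorophenyl group, has a modest bearing on the cytotoxicity read-out. The change is not a simple one, since dipentylamino has no ring and no hydrogen-bond donor, while benzylamino has fewer heavy atoms, a six-membered aromatic ring and a hydrogen-bond donor, and no evidence here ties the step to any one of these differences.

The compounds shown leave open which difference counts: with the 4-chlorophenyl group kept, pentylamino on the same carbon would carry the donor without the ring, and dibenzylamino would carry the ring without the donor. The separate contributions of the 4-chlorophenyl and phenyl groups also cannot be read, as compound 1 and compound 2 differ in more than one place.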